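Swapping propyl for 1-hydroxycyclohexyl in compound 3

The source may hold more compounds than are shown below. What is called first, only, known or untested is meant among the compounds shown, and "the series" means these compounds.

In a functional assay on IMR-32 cells (Homo sapiens) for antiproliferative activity, read by sulforhodamine B assay, with a stated time of 48 h (on this read-out lower numbers stand for stronger inhibition of growth and higher numbers for weaker inhibition of growth), compound 1 `COc1ccc(-c2cn(CCCN3C(=O)COc4ccccc43)nn2)cc1` gives 49900 nM, compound 2 `O=C1COc2ccccc2N1CCCn1cc(-c2cccnc2)nn1` gives 860 nM and compound 3 `CCCc1cn(CCCN2C(=O)COc3ccccc32)nn1` gives 1400 nM. Compound 3 stands with compound 2, as the data show a 1.6-fold higher number from compound 2 to compound 3 (0.21 log units; within the scatter). Compound 1 lies far from both, with a 58-fold lower number from compound 1 to compound 2 (1.76 log units; beyond the scatter) and a 36-fold lower number from compound 1 to compound 3 (1.55 log units; beyond the scatter).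

Compound 4 `O=C1COc2ccccc2N1CCCn1cc(C2(O)CCCCC2)nn1` keeps the shared core of compound 3 but carries 1-hydroxycyclohexyl in place of propyl on an aromatic carbon. Going by the values given here, no measured compound carries this new group, so only indirect guidance exists. The change from compound 1 to compound 3, a 36-fold lower number from compound 1 to compound 3 (1.55 log units; beyond the scatter), shows that a swap at this carbon can matter greatly. The change from compound 2 to compound 3, a 1.6-fold higher number from compound 2 to compound 3 (0.21 log units; within the scatter), shows that two quite different groups can also give values that cannot be told apart. A small upward move is therefore expected, namely an estimated 1.8-fold higher number from compound 3 to compound 4 (0.25 log units; within the scatter). For compound 4 the estimated value is 2500 nM, with an expected range of 700 nM to 15000 nM.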

Compound 4, concentration for 50% growth inhibition: 1200 nM
Compound 4: middle estimate off by 2.1-fold (0.32 log units), on the high side; the range from low to high includes it.
By their numbers in this assay, from the lowest: compounds 2, 4 and 3 (each within the scatter of the next); then compound 1.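

In this assay, a 1.2-fold lower number from compound 3 to compound 4 (0.07 log units; within the scatter) shows that this aromatic carbon accepts a larger group, with a six-membered ring and a hydrogen-bond donor, without a change that can be told from scatter. The a 1.4-fold higher number from compound 2 to compound 4 (0.14 log units; within the scatter) also places it with pyridin-3-yl, whereas a 42-fold lower number from compound 1 to compound 4 (1.62 log units; beyond the scatter) leaves 4-methoxyphenyl as the only group shown here that stands apart, so three quite different groups now share one level of growth inhibition. No supporting data here explain this tolerance or the gap to 4-methoxyphenyl.

The compounds shown leave open whether the hydroxyl of 1-hydroxycyclohexyl contributes anything, a question that plain cyclohexyl would address. They also leave open whether the weak value of compound 1 follows from the methoxy group or the phenyl ring, which unsubstituted phenyl would help separate.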